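A Methoxyphenyl Swap on a Lone Measured Compound

The source may hold more compounds than are shown below. What is called first, only, known or untested is meant among the compounds shown, and "the series" means these compounds.

Among the measured compounds shown here, in a functional assay on HL-60 cells (Homo sapiens) for inhibition, read by MTT assay, with a stated time of 72 h (a higher number here means a weaker inhibitor, a lower number a stronger inhibitor), compound 1 (`Cc1nc(-c2ccccc2F)c(C(=O)N2CCN(c3cc(Cl)ccc3C)CC2)o1`) gives 229 nM, the only number available so far. Compound 2 (`COc1ccc(-c2nc(C)oc2C(=O)N2CCN(c3cccc(Cl)c3)CC2)cc1OC`) is recorded as "not active" (no number reported), and compound 3 (`O=C(c1oc(C(F)(F)F)nc1-c1cccc(F)c1)N1CCN(c2cccc(Cl)c2)CC1`) is also recorded as "not active" (no number reported). Compound 4 (`COc1cccc(N2CCN(C(=O)c3oc(C)nc3-c3ccccc3F)CC2)c1`) keeps the core of compound 1, with 3-methoxyphenyl in place of 5-chloro-2-methylphenyl on an amine nitrogen in a ring. For the measured compounds named here, no measured pair differs in only one place, so this step has no direct precedent. Neither compound 2 nor compound 3 carries the 5-chloro-2-methylphenyl group, although both differ from compound 1 elsewhere too, so a weaker result is expected in this assay. The expected change is a 4.4-fold higher number from compound 1 to compound 4 (0.64 log units; beyond the scatter). The estimate for compound 4 is 1000 nM, within a range of 200 nM to 6000 nM.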

Compound 4, half-maximal inhibitory concentration: 56.1 nM
Estimate against measurement, compound 4: 18-fold (1.25 log units) above; the measured number lies below the stated range.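

In this assay the step is a 4.1-fold lower number from compound 1 to compound 4 (0.61 log units; beyond the scatter) and it runs towards a stronger inhibitor. At this position on the ring amine nitrogen, the shared core therefore keeps its activity without the chlorine and methyl of the 5-chloro-2-methylphenyl group, and 3-methoxyphenyl serves better in this pair. Nothing here offers an explanation for the step.

Still open, going by these compounds, is whether the methoxy group itself matters, or whether a plain phenyl would do as well. Also open, on these data alone, is how an amine or a carboxylic acid in its place would compare.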